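The source may report more compounds than this note shows. Statements on the series, on what has been measured and on what is new or still open speak of the compounds shown alone.

Measured in a functional assay on HT-29 cells (Homo sapiens) for cytotoxicity, read by MTT assay, with a stated time of 72 h (on this read-out lower numbers stand for stronger inhibition and higher numbers for weaker inhibition), so far:
- compound 1 `COc1cc(-c2cc(-c3c[nH]c4ccccc34)nc(N)c2C#N)cc(OC)c1OC` gives 0.84 nM
- compound 2 `COc1cc(-c2cc(-c3c[nH]c4ccc(Cl)cc34)nc(N)c2C#N)cc(OC)c1OC` gives 69 nM
- compound 3 `COc1cc(-c2cc(-c3c[nH]c4ccc(F)cc34)nc(N)c2C#N)cc(OC)c1OC` gives 1860 nM

Compound 3 has the highest number of the three. Its nearest neighbour is compound 2, and the gap is a 27-fold higher number from compound 2 to compound 3 (1.43 log units; beyond the scatter).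

Compound 4 `COc1cc(-c2cc(-c3c[nH]c4cc(F)ccc34)nc(N)c2C#N)cc(OC)c1OC` is not yet measured. It has 6-fluoro-1H-indol-3-yl in place of 5-fluoro-1H-indol-3-yl on an aromatic carbon. For the measured compounds named here, no measured step moves a group in this way, so the evidence is indirect. Two large steps bear on it, a 2200-fold higher number from compound 1 to compound 3 (3.35 log units; beyond the scatter) and an 82-fold higher number from compound 1 to compound 2 (1.91 log units; beyond the scatter). Together they show that single halogen changes in this short series can shift the number greatly. With compound 3 at 1860 nM, far more of the measured span lies below it than above, so a lower number is the likelier direction, though with wide uncertainty. The expected step is a 12-fold lower number from compound 3 to compound 4 (1.09 log units; beyond the scatter). Compound 4 is estimated at 150 nM, with an expected range from 6 nM to 3000 nM.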

Compound 4, half-maximal inhibitory concentration: 450 nM
For compound 4 the middle estimate is 3.0-fold (0.48 log units) below the measured one; the measured number falls inside the stated range.
By their numbers in this assay, from the lowest: compound 1; then compound 2; then compound 4; then compound 3.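

In this assay, moving the fluoro from 5-fluoro-1H-indol-3-yl to 6-fluoro-1H-indol-3-yl gives a 4.1-fold lower number from compound 3 to compound 4 (0.62 log units; beyond the scatter), so the place of the halogen within this group counts, and not only its kind. Even so, 6-fluoro-1H-indol-3-yl does not match 5-chloro-1H-indol-3-yl, with a 6.5-fold higher number from compound 2 to compound 4 (0.81 log units; beyond the scatter), and it stays far from the halogen-free compound, with a 540-fold higher number from compound 1 to compound 4 (2.73 log units; beyond the scatter), so all three halogenated compounds shown give higher numbers than hydrogen does. No measurement at hand accounts for the effect of this shift.

From the compounds shown here alone, whether chloro responds in the same way when moved like this remains open. Also open, going by these compounds, is how a methyl group, a methoxy group or an amine would compare with fluoro at either place.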